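Swapping the Aryl Group on the Cyclopropyl Core

The compounds below may be only part of what the source reports. "The series", "measured", "known", "first", "only" and "open" are said of these compounds alone.

Of the compounds shown here, three have been measured in a functional assay on A549 cells (Homo sapiens) for antiproliferative activity, read by MTT assay, with a stated time of 48 h; on this read-out lower numbers stand for stronger inhibition and higher numbers for weaker inhibition. Compound 1 `CCn1cc(-c2ccc(OC)cc2)c(=O)c2cc(F)c(N3CCNCC3)cc21` gives 11600 nM in this assay. Compound 2 `CCn1cc(-c2cccc(F)c2)c(=O)c2cc(F)c(N3CCNCC3)cc21` gives 3060 nM in this assay. Compound 3 `COc1ccc(-c2cn(C3CC3)c3cc(N4CCNCC4)c(F)cc3c2=O)cc1` gives 1870 nM in this assay, the lowest of the three numbers, although its gap to compound 2 lies within the scatter. Two single changes connect these compounds. The first, (3-fluorophenyl in place of 4-methoxyphenyl on an aromatic carbon), produced a 3.8-fold lower number from compound 1 to compound 2 (0.58 log units; beyond the scatter). The second, (cyclopropyl in place of ethyl on an aromatic nitrogen), produced a 6.2-fold lower number from compound 1 to compound 3 (0.79 log units; beyond the scatter); this is also how the core of compound 3 differs from the core of compound 1. Compound 4 `O=c1c(-c2cccc(F)c2)cn(C2CC2)c2cc(N3CCNCC3)c(F)cc12` has not been measured. It differs from compound 3 by 3-fluorophenyl in place of 4-methoxyphenyl on an aromatic carbon. For the measured compounds named here, this is the same kind of change as the one from compound 1 to compound 2, but not the same: in compound 1 the place is meta to an ethyl group (2 heavy atoms), whereas in compound 3 it is meta to a cyclopropyl group (3 heavy atoms). Compound 4 is expected to show a step of a 3.1-fold lower number from compound 3 to compound 4 (0.49 log units; beyond the scatter), somewhat smaller than the earlier 3.8-fold lower number from compound 1 to compound 2 (0.58 log units; beyond the scatter). The expectation rests on a 3.8-fold lower number from compound 1 to compound 2 (0.58 log units; beyond the scatter) alone; a single earlier instance and the differing surroundings leave room for a smaller step. Compound 4 is thus estimated at 600 nM, between 250 nM and 1500 nM.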

Compound 4, half-maximal inhibitory concentration: 1100 nM
Compound 4: middle estimate off by 1.8-fold (0.26 log units), on the low side; the measured number falls inside the stated range.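

Placing 3-fluorophenyl in place of 4-methoxyphenyl on the cyclopropyl core gave a 1.7-fold lower number from compound 3 to compound 4 (0.23 log units; within the scatter), so on this core the step alone cannot be told apart from repeat variation in this assay, yet it does not differ from the earlier step on the ethyl core: the same change on two cores in this assay, a 3.8-fold lower number (0.58 log units; beyond the scatter) from compound 1 to compound 2 and a 1.7-fold lower number (0.23 log units; within the scatter) from compound 3 to compound 4, 2.2-fold (0.35 log units) apart, within the scatter of two such steps. Cyclopropyl in place of ethyl on an aromatic nitrogen gave a 2.8-fold lower number from compound 2 to compound 4 (0.44 log units; beyond the scatter), and this change also carries from one core to the other without a difference that can be resolved: the same change on two cores in this assay, a 6.2-fold lower number (0.79 log units; beyond the scatter) from compound 1 to compound 3 and a 2.8-fold lower number (0.44 log units; beyond the scatter) from compound 2 to compound 4, 2.2-fold (0.35 log units) apart, within the scatter of two such steps. For the compounds shown here, the four compounds are thus consistent with both changes carrying across the two cores, but with only two instances of each change, they do not show that the steps are truly equal or that the aryl swap has a real effect on the cyclopropyl core.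

The compounds shown leave open how these steps would run with a longer chain on the aromatic nitrogen. They also leave open whether the aryl swap would carry over to a carboxylic acid or an amine on the aryl ring.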